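The compounds below may be only part of what the source reports. "The series", "measured", "known", "first", "only" and "open" are said of these compounds alone.

Measured so far:
- compound 1 `CCNC(=O)c1noc(-c2cc(C(C)C)c(O)cc2O)c1-c1cc(CNC(C)C)no1` gives 38 nM in a functional assay on A2780 cells (Homo sapiens) for inhibition; a lower number here means a stronger inhibitor, a higher number a weaker inhibitor
- compound 2 `CCNC(=O)c1noc(-c2cc(C(C)C)c(O)cc2O)c1-c1cc(CN2CCCCC2)no1` gives 62 nM in this assay

Compound 1 has the lowest of these two numbers, but compound 2 sits close: a 1.6-fold higher number from compound 1 to compound 2 (0.21 log units; within the scatter). Compound 3 `CCNC(=O)c1noc(-c2cc(C(C)C)c(O)cc2O)c1-c1cc(C(N)=O)no1` differs from compound 1 at the same spot, with carbamoyl in place of (isopropylamino)methyl on an aromatic carbon. Among the measured compounds shown here, the only measured step touches that spot, swapping one amine for another, and stayed within the scatter. For the measured compounds named here, a carbamoyl is a different kind of group, so no measured step tells how far this change reaches. A modest rise is expected, with wide uncertainty: for compound 3 the estimate is 80 nM, from 25 nM to 300 nM, a step of a 2.1-fold higher number from compound 1 to compound 3 (0.32 log units; beyond the scatter).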

Compound 3, half-maximal inhibitory concentration: 15 nM
Estimate against measurement, compound 3: 5.3-fold (0.73 log units) above, outside the stated range (below it).
By their numbers in this assay, from the lowest: compound 3; then compounds 1 and 2 (each within the scatter of the next).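

Replacing the amine side chain with carbamoyl on this aromatic carbon gives a 2.5-fold lower number from compound 1 to compound 3 (0.40 log units; beyond the scatter) and a 4.1-fold lower number from compound 2 to compound 3 (0.62 log units; beyond the scatter) in this assay. The swap between amines had shown no change beyond the scatter, whereas this result shows that the position responds to a different kind of group and that an amine on a saturated chain carbon is not required for activity. No evidence here explains this gain. On these data alone, whether the carbonyl or the amide nitrogen matters more stays open, as does how a carboxylic acid, a methyl ester or a longer chain ending in carbamoyl would behave at this spot.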